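This account rests on a few compounds, and the source may have more. Where it says the series, first, only, none or still open, it means among the compounds named here.

Compound 3 `Cc1ccc(-n2nncc2CN2C(=O)C3(C(C#N)=C(N)Oc4c(N)cc5nc6ccccc6nc5c43)c3ccccc32)cc1Cl` shares its core with compound 1 `Cc1ccc(C)c(-n2nncc2CN2C(=O)C3(C(C#N)=C(N)Oc4c(N)cc5nc6ccccc6nc5c43)c3ccccc32)c1` and compound 2 `N#CC1=C(N)Oc2c(N)cc3nc4ccccc4nc3c2C12C(=O)N(Cc1cnnn1-c1c(F)cccc1F)c1ccccc12`, the three differing only in the aryl group on the aromatic nitrogen. In a functional assay on HCT-116 cells (Homo sapiens) for antiproliferative activity, read by MTT assay, with a stated time of 48 h (on this read-out lower numbers stand for stronger inhibition and higher numbers for weaker inhibition), compound 3 gives only a limit, > 50000 nM. Compound 1 also gives only a limit, > 50000 nM. Compound 2 likewise gives only a limit, > 50000 nM. The steps a step that the two limits leave unreadable from compound 1 to compound 2, a step that the two limits leave unreadable from compound 1 to compound 3 and a step that the two limits leave unreadable from compound 2 to compound 3 are unreadable because every value sits at the limit of > 50000 nM in this assay, at which 3 of the 3 values shown sit. Compound 4 `N#CC1=C(N)Oc2c(N)cc3nc4ccccc4nc3c2C12C(=O)N(Cc1cnnn1-c1ccc([N+](=O)[O-])cc1[N+](=O)[O-])c1ccccc12` differs from compound 3 by 2,4-dinitrophenyl in place of 3-chloro-4-methylphenyl on an aromatic nitrogen. Among the measured compounds shown here, no measured step speaks readably to this change, so the numbers give no direction for it. Compound 4 is expected to stay at the limit, estimated at 50000 nM with a range from 20000 nM to 200000 nM. The expected step of a number no higher from compound 3 to compound 4 (the limit leaves the size open) is accordingly no change beyond the scatter.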

Compound 4, half-maximal inhibitory concentration: 23900 nM
Compound 4: middle estimate off by 2.1-fold (0.32 log units), on the high side; the range from low to high includes it.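

In this assay, the aromatic nitrogen of the triazole-type ring proves able to move the number: 2,4-dinitrophenyl gives an at least 2.0-fold lower number from compound 3 to compound 4 (0.32 log units; beyond the scatter), an at least 2.0-fold lower number from compound 2 to compound 4 (0.32 log units; beyond the scatter) and an at least 2.0-fold lower number from compound 1 to compound 4 (0.32 log units; beyond the scatter). The steps among compound 1, compound 2 and compound 3 could not be read, and only compound 4 leaves the shared ceiling: the limit of > 50000 nM in this assay, at which 3 of the 4 values shown sit.

Going by these compounds, the true sizes of these steps stay open, as does whether both nitro groups take part. Also open, on these data alone, is whether a phenyl ring carrying a nitrile or a carboxylic acid instead would give a lower number.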